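The source may report more compounds than this note shows. Statements on the series, on what has been measured and on what is new or still open speak of the compounds shown alone.

Measured in a functional assay on RS4-11 cells (Homo sapiens) for inhibition, read by CCK-8 assay, with a stated time of 48 h; a higher number here means a weaker inhibitor, a lower number a stronger inhibitor:
compound 1 `O=C(NCCNS(=O)(=O)c1ccc(-c2ccccc2OCc2cccc(O)c2)s1)Nc1cc(C(F)(F)F)cc(C(F)(F)F)c1` gives 3000 nM
compound 2 `Cc1cc(C)cc(NC(=O)NCCNS(=O)(=O)c2ccc(-c3ccccc3OCc3cccc(O)c3)s2)c1` gives 5800 nM
compound 3 `Nc1ccc(Oc2ccccc2-c2ccc(S(=O)(=O)NCCNC(=O)Nc3cc(C(F)(F)F)cc(C(F)(F)F)c3)s2)cc1` gives 11900 nM

Compound 1 and compound 3 share one core and differ in a single place: 4-aminophenyl in place of 3-hydroxybenzyl on an oxygen on an aromatic ring. This change produced a 4.0-fold higher number from compound 1 to compound 3 (0.60 log units; beyond the scatter). Compound 2 rests on a different core; the difference between the two cores is not broken down here. In this assay compound 2 lies within the scatter of compound 1 and beyond the scatter relative to compound 3.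

Compound 4 `Cc1cc(C)cc(NC(=O)NCCNS(=O)(=O)c2ccc(-c3ccccc3Oc3ccc(N)cc3)s2)c1` is not yet measured. It stands to compound 2 as compound 3 stands to compound 1, the same change at the same place: 4-aminophenyl in place of 3-hydroxybenzyl on an oxygen on an aromatic ring.

Going by the values given here, the step is expected to be about a 3.8-fold higher number from compound 2 to compound 4 (0.58 log units; beyond the scatter), resting on the single earlier pair, where the change gave a 4.0-fold higher number from compound 1 to compound 3 (0.60 log units; beyond the scatter). Compound 4 is therefore estimated at 22000 nM in this assay, with a plausible range from 9000 nM to 55000 nM.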

Compound 4, half-maximal inhibitory concentration: > 20000 nM
Compound 4: no number, only a limit; the forecaster's own chance of this, stated with the estimate: 20%; the middle value lies beyond the limit too.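

In this assay compound 4 gives > 20000 nM, which is a limit of the assay and not a number. The step, an at least 3.4-fold higher number from compound 2 to compound 4 (0.53 log units; beyond the scatter), shows that 4-aminophenyl in place of 3-hydroxybenzyl moves the number the same way on both cores: the same change on two cores in this assay, a 4.0-fold higher number (0.60 log units; beyond the scatter) from compound 1 to compound 3 and an at least 3.4-fold higher number (0.53 log units; beyond the scatter) from compound 2 to compound 4; the limit leaves it open whether they differ Direction therefore carries from one core to the other in these two pairs, but equal size is not shown, and two pairs set no rule for the wider series.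

Going by these compounds, the true position of compound 4 remains open. Also open, on these data alone, is whether a 4-hydroxyphenyl or 3-aminobenzyl group on the same oxygen would separate the swap of hydroxyl for amine from the change from benzyl to phenyl.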